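Swapping the benzyl thioether arm on a low-toxicity core

The source may hold more compounds than are shown below. What is called first, only, known or untested is meant among the compounds shown, and "the series" means these compounds.

Compound 1 `Cn1cc(SCc2nnc(S)n2-c2c(Cl)cccc2Cl)c2ccccc21` is the parent of this small set. In a toxicity assay on HEK-293T cells (Homo sapiens) for cytotoxicity, read by CCK-8 assay, with a stated time of 48 h (on this read-out higher numbers stand for lower toxicity in this test and lower numbers for higher toxicity in this test), compound 1 gives > 100000 nM, which is a limit of the assay rather than a number. Compound 2 `Cn1cc(SCc2nnc(SCc3c(F)cccc3Cl)n2-c2c(Cl)cccc2Cl)c2ccccc21` carries a 2-chloro-6-fluorobenzyl in place of hydrogen on a sulfur. In this assay compound 2 gives > 100000 nM, again a limit and not a number. The step that the two limits leave unreadable from compound 1 to compound 2 therefore cannot be sized, since both ends rest at the limit of > 100000 nM in this assay, at which 2 of the 2 values shown sit. Compound 3 `Cn1cc(SCc2nnc(SCc3ccc(Cl)cc3C(F)(F)F)n2-c2c(Cl)cccc2Cl)c2ccccc21` differs from compound 2 by 4-chloro-2-(trifluoromethyl)phenyl in place of 2-chloro-6-fluorophenyl on a saturated chain carbon bound to a sulfur. For the measured compounds named here, the only measured step is unreadable, so no direction or size beyond the scatter can be drawn from it for this change. Both measured compounds sit at the same limit, and compound 3 is expected to do the same, with an expected step of a number no higher from compound 2 to compound 3 (the limit leaves the size open). For compound 3 in this assay the estimate is 100000 nM, with a range from 40000 nM to 300000 nM.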

Compound 3, half-maximal cytotoxic concentration: 56500 nM
For compound 3 the middle estimate is 1.8-fold (0.25 log units) above the measured one; the measured number falls inside the stated range.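

In this assay, for the compounds shown here, compound 3 is the only compound here that gives a number rather than a limit, so a change at this position can produce a reading inside the range of the test. Replacing 2-chloro-6-fluorophenyl with 4-chloro-2-(trifluoromethyl)phenyl gives an at least 1.7-fold lower number from compound 2 to compound 3 (0.24 log units; that floor lies within the scatter), and adding the whole 4-chloro-2-(trifluoromethyl)benzyl in place of hydrogen on the sulfur gives an at least 1.7-fold lower number from compound 1 to compound 3 (0.24 log units; that floor lies within the scatter). Both steps are floors rather than full sizes, and the other compounds remain at the limit: the limit of > 100000 nM in this assay, at which 2 of the 3 values shown sit.

The compounds shown do not tell whether the trifluoromethyl or the chlorine of the new ring goes with this step. Also open, going by these compounds, is how an amine or a carboxylic acid on the benzyl ring, or a longer chain in its place, would read in this assay.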